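A few compounds are considered here, and "the series" means these few. Any claim that something is new, unique, unknown or untested is made for them only; others in the source may bear on it.

Compound 2 `C=CS(=O)(=O)c1cc(C(F)(F)F)cc(C(F)(F)F)c1` is one of three compounds that share a core carrying two trifluoromethyl groups. In an ADME assay for pharmacokinetics, read by HPLC, in phosphate buffer, with a stated time of 72 h, at pH 7.4, tested at 250 uM (a lower number here means that the compound disappears faster, a higher number that the compound lasts longer), compound 2 reaches only a limit of the assay, < 0.017 h. Compound 1 `C=CC(=O)Nc1cc(C(F)(F)F)cc(C(F)(F)F)c1` gives 4.2 h in this assay. Compound 3 `O=C(CBr)c1cc(C(F)(F)F)cc(C(F)(F)F)c1` also reaches only a limit, < 0.017 h. So compound 2 sits at the limit of < 0.017 h in this assay, at which 2 of the 3 values shown sit, and the two steps that lead there are large: an at least 240-fold lower number from compound 1 to compound 2 (2.39 log units; beyond the scatter) and an at least 240-fold lower number from compound 1 to compound 3 (2.39 log units; beyond the scatter). The remaining step is a step that the two limits leave unreadable from compound 2 to compound 3.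

Compound 4 `Fc1cc(C(F)(F)F)cc(C(F)(F)F)c1` is not yet measured. It differs from compound 2 in that (fluoro in place of vinylsulfonyl on an aromatic carbon). Within the data shown here, none of the measured steps covers this exchange: each of them swaps one group of several heavy atoms for another, whereas here the vinylsulfonyl gives way to a single fluorine. Among the measured compounds shown here, the only measured compound that carries neither vinylsulfonyl nor (bromomethyl)carbonyl at this position is compound 1, which gives 4.2 h in this assay. Compound 4 is therefore expected to move upward from the limit, a step estimated at an at least 4200-fold higher number from compound 2 to compound 4 (3.62 log units; beyond the scatter), with wide uncertainty. The estimate for compound 4 is 72 h, expected to fall between 8 h and 500 h.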

Compound 4, half-life: 11 h
Compound 4: the middle estimate sits 6.5-fold (0.82 log units) above what was measured, and the stated range covers the measured number.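

Compound 2 and compound 3 stand at a limit in this assay, not at a readable number: the limit of < 0.017 h in this assay, at which 2 of the 4 values shown sit. With fluoro on this aromatic carbon the compound lasts far longer, and the two steps are an at least 640-fold higher number from compound 2 to compound 4 (2.81 log units; beyond the scatter) and an at least 640-fold higher number from compound 3 to compound 4 (2.81 log units; beyond the scatter), each of them a minimum that starts from a limit. The comparison with the one earlier compound that lasted adds something new, a 2.6-fold higher number from compound 1 to compound 4 (0.42 log units; beyond the scatter), so a long half-life at this position does not depend on the (vinylcarbonyl)amino of compound 1, and among the four compounds shown, only those with vinylsulfonyl or (bromomethyl)carbonyl disappear too fast to read.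

The compounds shown leave open how other groups on this aromatic carbon would behave in this assay, for example an amine, a nitrile or a carboxylic acid, and whether any of them would fall in the wide gap between the limit and the readable values. Going by these compounds, the step between compound 2 and compound 3 cannot be read, so how these two compare remains unknown.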